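The source may report more compounds than this note shows. Statements on the series, on what has been measured and on what is new or still open speak of the compounds shown alone.

Measured so far in a functional assay on ACHN cells (Homo sapiens) for antiproliferative activity, read by sulforhodamine B assay; on this read-out lower numbers stand for stronger inhibition of growth and higher numbers for weaker inhibition of growth:
- Compound 1 `COc1cccc(OCCC(C)(C)C)c1C(=O)/C=C/c1ccc(O)cc1`: > 30000 nM (a limit of the assay)
- Compound 2 `CC(C)(C)CCOc1cccc(O)c1C(=O)/C=C/c1ccc(C(=O)O)cc1`: 8450 nM
- Compound 3 `CC(C)(C)CCOc1cccc(O)c1C(=O)/C=C/c1ccc(O)cc1`: 3140 nM

Of the two true numbers in this assay, compound 3 has the lower, at 3140 nM, and compound 2 follows at 8450 nM. Compound 1 gives only a limit, > 30000 nM.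

Compound 4 `O=C(/C=C/c1ccc(O)cc1)c1c(O)cccc1OCCC1CCCCC1` differs from compound 3 in one place: cyclohexyl in place of tert-butyl on a saturated chain carbon, two bonds along the chain from an oxygen on an aromatic ring. The 3,3-dimethylbutoxy group thus becomes 2-cyclohexylethoxy.

Neither measured step touches this chain, so both bear on the change only indirectly. One is an at least 9.5-fold lower number from compound 1 to compound 3 (0.98 log units; beyond the scatter), with hydrogen in place of methyl on an oxygen on an aromatic ring. The other is a 2.7-fold lower number from compound 2 to compound 3 (0.43 log units; beyond the scatter), with hydroxy in place of carboxy on an aromatic carbon. For the measured compounds named here, with no measured precedent for the chain, a small step of uncertain direction is expected in this assay, possibly none beyond the scatter, leaving compound 4 close to compound 3 at 3140 nM.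

The expected change is a 1.2-fold lower number from compound 3 to compound 4 (0.07 log units; within the scatter). Compound 4 is estimated at 2700 nM, with an expected range of 1000 nM to 7500 nM.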

Compound 4, concentration for 50% growth inhibition: > 30000 nM
Compound 4 was reported as a limit; the forecaster's own chance of this, stated with the estimate: 5%; middle value at least 11-fold (1.04 log units) from the limit.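

In this assay, the end of the chain turns out not to be a neutral place: cyclohexyl in place of tert-butyl, with the rest of the molecule unchanged, gives an at least 9.5-fold higher number from compound 3 to compound 4 (0.98 log units; beyond the scatter). For the compounds shown here, the value of compound 4, > 30000 nM, is a limit of the assay, so this step has a lower bound but no measured size, and the value is not alone there: the limit of > 30000 nM in this assay, at which 2 of the 4 values shown sit. The earlier steps changed only the methyl on an oxygen and the carboxy group, whereas this one shows that the 3,3-dimethylbutoxy group alone can separate a measurable compound from one at the limit.

On these data alone, what stays open is whether the ring itself or the larger count of carbon atoms goes with this change. A straight hexyl chain, a phenyl group or a terminal amine at the same place would be needed to tell these apart.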